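From 2-chlorophenyl to 3-chlorophenyl: compound 3 and compound 4

This account rests on a few compounds, and the source may have more. Where it says the series, first, only, none or still open, it means among the compounds named here.

Measured in a functional assay on HepG2 cells (Homo sapiens) for inhibition, read by MTT assay; a higher number here means a weaker inhibitor, a lower number a stronger inhibitor:
- compound 1 `COc1cc2ncnc(Nc3ccc(NC(=O)c4cccc(C)c4)cc3)c2cc1OC` gives 7500 nM
- compound 2 `COc1cc2ncnc(Nc3ccc(NC(=O)c4ccccc4OC)cc3)c2cc1OC` gives > 100000 nM
- compound 3 `COc1cc2ncnc(Nc3ccc(NC(=O)c4ccccc4Cl)cc3)c2cc1OC` gives 26000 nM

The entry for compound 2 is a limit of the assay, not a number. Of the two numeric values, compound 3 stands higher, and compound 1 is its nearest neighbour.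

Compound 4 `COc1cc2ncnc(Nc3ccc(NC(=O)c4cccc(Cl)c4)cc3)c2cc1OC` has 3-chlorophenyl in place of 2-chlorophenyl on a carbonyl carbon. For the measured compounds named here, no measured step isolates this change. The closest is a 3.5-fold higher number from compound 1 to compound 3 (0.54 log units; beyond the scatter), with 2-chlorophenyl in place of 3-methylphenyl. an at least 13-fold higher number from compound 1 to compound 2 (1.12 log units; beyond the scatter) runs the same way, with 2-methoxyphenyl in place of 3-methylphenyl. an at least 3.8-fold lower number from compound 2 to compound 3 (0.58 log units; beyond the scatter) shows that the number also depends on the group itself, so compound 4 need not match compound 1 exactly. A modest move towards a lower number in this assay is therefore expected, and the expected step is a 2.4-fold lower number from compound 3 to compound 4 (0.37 log units; beyond the scatter). For compound 4 the estimated value is 11000 nM, with an expected range from 3500 nM to 32000 nM.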

Compound 4, half-maximal inhibitory concentration: 12000 nM
Compound 4: the middle estimate sits 1.1-fold (0.04 log units) below what was measured, within the range that was stated.
By their numbers in this assay, from the lowest: compounds 1 and 4 (each within the scatter of the next); then compound 3. At a limit, above all of these: compound 2.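

In this assay, for the compounds shown here, 3-chlorophenyl in place of 2-chlorophenyl on a carbonyl carbon gives a 2.2-fold lower number from compound 3 to compound 4 (0.34 log units; beyond the scatter), the first step that changes only where the chloro sits, with the same atoms joined differently. Chloro in place of methyl on an aromatic carbon gives a 1.6-fold higher number from compound 1 to compound 4 (0.20 log units; within the scatter), so this assay does not separate 3-chlorophenyl from 3-methylphenyl. 3-Chlorophenyl in place of 2-methoxyphenyl gives an at least 8.3-fold lower number from compound 2 to compound 4 (0.92 log units; beyond the scatter), but this step rests on a limit for compound 2, not a number: the limit of > 100000 nM in this assay, at which 1 of the 4 values shown sits.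

Open, as far as these compounds go, is whether the same change holds for another group, as 3-methoxyphenyl in place of 2-methoxyphenyl would show. Also open, from the compounds shown here alone, is whether an amine or a carboxylic acid on the phenyl ring would move the number beyond the scatter from compound 4.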